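Azidomethyl to prop-1-en-1-yl on the carbonyl carbon

The source may report more compounds than this note shows. Statements on the series, on what has been measured and on what is new or still open speak of the compounds shown alone.

Compound 1 `COc1ccc(CN(C(=O)CCl)c2cc(OC)c(OC)c(OC)c2)cc1O` gives 250 nM in a functional assay on HCT-116 cells (Homo sapiens) for inhibition, read by MTT assay, with a stated time of 48 h; a higher number here means a weaker inhibitor, a lower number a stronger inhibitor
Compound 2 `COc1ccc(CN(C(=O)CN=[N+]=[N-])c2cc(OC)c(OC)c(OC)c2)cc1O` gives 410 nM in this assay
Compound 3 `C/C=C/C(=O)N(Cc1ccc(OC)c(O)c1)c1cc(OC)c(OC)c(OC)c1` has no value yet

Going by the values given here, compound 2, at 410 nM in this assay, stands within the scatter of compound 1, its only measured neighbour. The next change gives compound 3: prop-1-en-1-yl in place of azidomethyl on a carbonyl carbon.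

Among the compounds with values here, only one measured step bears on this, a 1.6-fold higher number from compound 1 to compound 2 (0.21 log units; within the scatter), where azido took the place of chloro on a saturated chain carbon bound to a carbonyl carbon. That step lies within the scatter, so swapping that substituent left no clear mark on the numbers. Within the data shown here, it is weak evidence, however, since compound 3 replaces the whole azidomethyl group and no measured compound carries prop-1-en-1-yl. No step beyond the scatter is therefore expected, in either direction, though with wide uncertainty. The expected change is a 1.1-fold higher number from compound 2 to compound 3 (0.04 log units; within the scatter) in this estimate. For compound 3 the estimated value is 450 nM, with an expected range of 150 nM to 1400 nM in this assay once measured.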

Compound 3, half-maximal inhibitory concentration: 55 nM
Compound 3: middle estimate off by 8.2-fold (0.91 log units), on the high side, and the stated range ends above it.
By their numbers in this assay, from the lowest: compound 3; then compounds 1 and 2 (each within the scatter of the next).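

At the carbonyl carbon whose other neighbour is the amide-type nitrogen, the group carried there does move the number in this assay: the change from azidomethyl gives a 7.5-fold lower number from compound 2 to compound 3 (0.87 log units; beyond the scatter), and the change from chloromethyl gives a 4.5-fold lower number from compound 1 to compound 3 (0.66 log units; beyond the scatter), both beyond the scatter. The earlier step from chloro to azido stayed within the scatter, so that pair alone made this position look tolerant of change, whereas replacing the whole group with prop-1-en-1-yl shows that it is not indifferent to what it carries; compound 3 is the strongest inhibitor of the three in these cells, though on one example of the new group.
No supporting measurement bears on why this replacement lowers the number.

Open, as far as these compounds go, is whether the double bond of prop-1-en-1-yl matters or only the loss of the chloro or azido group, a question that a saturated propyl group at the same place would separate. Also open, from the compounds shown here alone, is how the position would respond to a chain carrying an amine or a carboxylic acid, or to a longer chain with the double bond kept.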